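Phenyl for ethyl on the triazole nitrogen: a second look

A few compounds are considered here, and "the series" means these few. Any claim that something is new, unique, unknown or untested is made for them only; others in the source may bear on it.

Of the compounds shown here, three have been measured in a functional assay on the whole organism (strain albino) for inhibition, with Rattus norvegicus as the target, read by paw edema, with stated times of 30 min and 5 h, at a dose of 0.28 mmol/kg by the oral route; a higher number here means more inhibition at the dose given (going by the name of the read-out), a lower number less inhibition. Compound 1 `CCn1c(SCC(=O)Nc2ccc(C(C)=O)cc2)nnc1-c1ccc(OC)cc1` gives 62%. Compound 2 `COc1ccc(-c2nnc(SCC(=O)Nc3ccc(C(C)=O)cc3)n2-c2ccccc2)cc1` gives 60%, and compound 3 `CCn1c(SCC(=O)Nc2ccc(C(C)=O)cc2)nnc1-c1ccccc1` gives 66%. Compound 4 `CC(=O)c1ccc(NC(=O)CSc2nnc(-c3ccccc3)n2-c2ccccc2)cc1` has not yet been measured.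

Compound 2 arises from compound 1 by phenyl in place of ethyl on an aromatic nitrogen, and this gave a number 2 percentage points lower from compound 1 to compound 2 (within the scatter). Compound 3 arises from compound 1 by hydrogen in place of methoxy on an aromatic carbon, and this gave a number 4 percentage points higher from compound 1 to compound 3 (within the scatter). The three measured numbers thus lie close to one another, within the scatter, and count as level.

Compound 4 arises from compound 3 by phenyl in place of ethyl on an aromatic nitrogen. This is the same kind of change as that from compound 1 to compound 2, but not the same: in compound 1 the ethyl sits next to the ring atom that bears a 4-methoxyphenyl group, whereas in compound 3 it sits next to the ring atom that bears a phenyl group. The two cores differ by the change from compound 1 to compound 3, given above.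

The earlier instance of this change was within the scatter, so a step of similar size is expected, namely a number 2 percentage points lower from compound 3 to compound 4 (within the scatter). This rests on compound 1 and compound 2, whose step was a number 2 percentage points lower from compound 1 to compound 2 (within the scatter). Compound 4 is therefore estimated to give 64% in this assay, most likely between 52% and 76%.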

Compound 4, a percentage reported as inhibition, in the whole organism at one dose (the size of the read-out at that dose, not a potency): 63%
Compound 4: middle estimate off by 1 percentage points, on the high side, within the range that was stated.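

In this assay, phenyl in place of ethyl on the aromatic nitrogen gave a number 3 percentage points lower from compound 3 to compound 4 (within the scatter), and this step reads the same as the earlier one on the core of compound 1: the same change on two cores in this assay, a number 2 percentage points lower (within the scatter) from compound 1 to compound 2 and a number 3 percentage points lower (within the scatter) from compound 3 to compound 4, 1 percentage points apart, within the scatter of two such steps. Hydrogen in place of methoxy on an aromatic carbon, now with phenyl on that nitrogen, gave a number 3 percentage points higher from compound 2 to compound 4 (within the scatter), which likewise matches its earlier counterpart: the same change on two cores in this assay, a number 4 percentage points higher (within the scatter) from compound 1 to compound 3 and a number 3 percentage points higher (within the scatter) from compound 2 to compound 4, 1 percentage points apart, within the scatter of two such steps. For the compounds shown here, all four steps lie within the scatter, so the series shows only that neither change produced a readable shift on either core at this single dose; it does not show that a change with a real effect would carry from one core to another, nor does it say anything about potency.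

The compounds shown leave open whether another group on the aromatic nitrogen, such as benzyl or a longer chain, or another group in place of methoxy, such as chlorine or an amine, would move the number beyond the scatter. They also leave open what happens when the acetyl group shared by all four compounds gives way to another group, such as a carboxylic acid.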